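A few compounds are considered here, and "the series" means these few. Any claim that something is new, unique, unknown or untested is made for them only; others in the source may bear on it.

The study so far holds two measured compounds in an assay on isolated protein for inhibition of STE20-like serine/threonine-protein kinase (Homo sapiens), read by thermal shift assay, tested at 10 uM; a lower number here means that the compound stabilises the target less, a higher number that the compound stabilises the target more against heat. Within the data shown here, compound 1 `CC(C)(C)c1cc(NC(=O)Nc2ccc(Cl)cc2)n(-c2ccc(C#N)cc2)n1` and compound 2 `O=C(Nc1ccc(Cl)cc1)Nc1cc(C2CC2)nn1-c1ccc(OC(F)(F)F)cc1` share the same core and the same chlorophenyl urea; in this assay compound 1 gives 1.6 degrees C, and compound 2 gives 0.3 degrees C. Compound 2 thus stands lowest of the two numbers, with compound 1 as its only neighbour, a step above it that lies beyond the usual scatter. Compound 3 `N#Cc1ccc(-n2nc(C3CC3)cc2NC(=O)Nc2ccc(Cl)cc2)cc1` has not yet been measured in this assay. It differs from compound 2 in one place: cyano in place of trifluoromethoxy on an aromatic carbon, on an aromatic carbon of a six-membered aromatic ring of carbon only, para to a large group. Among the measured compounds shown here, no step between measured compounds isolates this exchange. Compound 1 carries the same cyano group and gives the higher of the two shifts, though it differs from compound 3 elsewhere as well, so its number only shows that cyano can go with a measurable shift. For compound 3 the step from compound 2 is expected to be a small upward one, a number 0.70 degrees C higher from compound 2 to compound 3 (within the scatter). The estimated shift for compound 3 in this assay is 1 degrees C, expected to fall between 0 degrees C and 2.3 degrees C.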

Compound 3, shift of the target's melting temperature: 0.7 degrees C
Estimate against measurement, compound 3: 0.30 degrees C above; the range from low to high includes it.
By their numbers in this assay, from the lowest: compounds 2, 3 and 1 (each within the scatter of the next, the first and the last beyond it).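

In this assay, among these compounds, the exchange of trifluoromethoxy for cyano on an aromatic carbon, para to a large group, gives a number 0.40 degrees C higher from compound 2 to compound 3 (within the scatter), the first reading of this position with everything else held constant; the smaller cyano, with 2 heavy atoms against 5, is thus not separated from trifluoromethoxy in this read-out. Among the compounds shown here, the same compound also gives the first reading of the other site, where cyclopropyl in place of tert-butyl on an aromatic carbon gives a number 0.90 degrees C lower from compound 1 to compound 3 (within the scatter), so neither single exchange on its own leaves the scatter, and these two steps alone do not show that either site matters for the shift. Nothing measured on these compounds bears on why the steps are as they are.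

The compounds shown leave open whether an amine or a carboxylic acid on this aromatic carbon, or a longer chain in the place of cyclopropyl, would give a step beyond the scatter. They also leave open whether the exchange of trifluoromethoxy for cyano gives a similar step when tert-butyl, rather than cyclopropyl, is present.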